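The compounds below may be only part of what the source reports. "The series", "measured", "known", "first", "only" and "open" are said of these compounds alone.

Compound 3, `CC(=O)N1CCC(c2cncc(N3C(=O)c4ccc(Cl)cc4C3(C)C)c2)CC1`, gives 5 nM in an assay on cells for inhibition of cytochrome P450 11B2, mitochondrial (Homo sapiens), read by HTRF; on this read-out lower numbers stand for stronger inhibition and higher numbers for weaker inhibition. Among the three compounds measured it stands second highest. Its nearest neighbour is compound 1, `CCS(=O)(=O)N1CCC(c2cncc(N3C(=O)c4ccc(Cl)cc4C3(C)C)c2)CC1`, which in this assay gives 3 nM; the step of a 1.7-fold higher number from compound 1 to compound 3 (0.22 log units; within the scatter) lies within the scatter. Furthest away is compound 2, `CC1CN(c2cccnc2)C(=O)c2ccc(Cl)cc21`, which in this assay gives 164 nM, a number well beyond the scatter from that of compound 3.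

Compound 4, `CCC(=O)NCc1cncc(N2C(=O)c3ccc(Cl)cc3C2(C)C)c1`, differs from compound 3 in one place: (propanoylamino)methyl in place of 1-acetylpiperidin-4-yl on an aromatic carbon. For the measured compounds named here, the only measured step that touches the same region is the one from compound 1 to compound 3, which swapped the acyl on the amine nitrogen in the ring and moved the number by a 1.7-fold higher number from compound 1 to compound 3 (0.22 log units; within the scatter), within the scatter. Going by the values given here, no measured pair shows what happens when the six-membered non-aromatic ring is removed and a chain with a hydrogen-bond donor takes its place. Among the compounds with values here, the values of compound 2 and compound 3 show only that the whole group at that position matters for the number. A modest rise, beyond the scatter, is therefore expected. Compound 4 is expected to give 15 nM, with a range from 5 nM to 50 nM. The estimate amounts to an expected step of a 3.0-fold higher number from compound 3 to compound 4 (0.48 log units; beyond the scatter).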

Compound 4, half-maximal inhibitory concentration: 282 nM
For compound 4 the middle estimate is 19-fold (1.27 log units) below the measured one, outside the stated range (above it).
By their numbers in this assay, from the lowest: compounds 1 and 3 (each within the scatter of the next); then compounds 2 and 4 (each within the scatter of the next).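

In this assay, replacing 1-acetylpiperidin-4-yl with (propanoylamino)methyl on this aromatic carbon gives a 56-fold higher number from compound 3 to compound 4 (1.75 log units; beyond the scatter) and thus shows that the number depends strongly on the group held at this position. The earlier step changed only the acyl group on the amine nitrogen of the ring and gave a 1.7-fold higher number from compound 1 to compound 3 (0.22 log units; within the scatter), so it left the ring in place and showed tolerance for that one exchange, not for loss of the whole group. With the six-membered non-aromatic ring gone and a chain bearing a hydrogen-bond donor in its place, the inhibition is far weaker, although no measurement shown here explains this large rise.

The ring, the amide hydrogen and the overall size of the group all change together in this single step, so the compounds shown cannot say which of these differences accounts for the result. On these data alone, it also remains open whether a longer chain, a methyl group on the amide nitrogen or a free amine on the piperidine ring would restore any of the lost inhibition at this position.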